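Swapping the aryl group on an inactive chalcone-type series

The source may report more compounds than this note shows. Statements on the series, on what has been measured and on what is new or still open speak of the compounds shown alone.

In a functional assay on A549 cells (Homo sapiens) for cytotoxicity, read by MTT assay, with a stated time of 72 h (a lower number here means a stronger inhibitor, a higher number a weaker inhibitor), compound 1 (`CNC(=O)c1cc(Oc2ccc(C(=O)/C=C/c3ccc(Br)cc3)cc2)ccn1`) gives > 50000 nM, which is a limit of the assay. Compound 2 (`CNC(=O)c1cc(Oc2ccc(C(=O)/C=C/c3ccc([N+](=O)[O-])cc3)cc2)ccn1`) gives > 50000 nM, again a limit and not a number. Going by the values given here, compound 2 therefore has no measured position of its own, and the series so far rests on (the limit of > 50000 nM in this assay, at which 2 of the 2 values shown sit).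

The next structure, compound 3 (`CNC(=O)c1cc(Oc2ccc(C(=O)/C=C/c3ccc(F)cc3Cl)cc2)ccn1`), carries 2-chloro-4-fluorophenyl in place of 4-nitrophenyl on a double-bonded chain carbon bound to a double-bonded chain carbon.

Among the compounds with values here, only one measured step bears on this change: a step that the two limits leave unreadable from compound 1 to compound 2. That step has no readable size, so it offers neither a magnitude nor a direction to carry over. Within the data shown here, no defined step is therefore expected in this assay, and the working expectation is that the new compound stays close to the same limit, with a fair chance of reporting only a limit again. The estimated step is an at least 1.1-fold lower number from compound 2 to compound 3 (0.04 log units; that floor lies within the scatter). For compound 3 the expected value is 45000 nM, with an estimated range of 12000 nM to 80000 nM.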

Compound 3, half-maximal inhibitory concentration: 21100 nM
The estimate for compound 3 lay 2.1-fold (0.33 log units) above the measured number; low and high end bracket the measured number.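

At this place on the double-bonded chain carbon, 2-chloro-4-fluorophenyl gives the series its first readable number in this assay, with an at least 2.3-fold lower number from compound 2 to compound 3 (0.37 log units; beyond the scatter) and an at least 2.3-fold lower number from compound 1 to compound 3 (0.37 log units; beyond the scatter). Both steps are floors set by limits of the assay, so the real size may be larger, while the step between the two limit compounds cannot be read. The aryl group at this place can therefore move the read-out off the limit, which 4-bromophenyl and 4-nitrophenyl do not show, and the rest of the series still stands at that limit: the limit of > 50000 nM in this assay, at which 2 of the 3 values shown sit.

As far as these compounds go, whether the chlorine or the fluorine of 2-chloro-4-fluorophenyl would carry the step alone stays open, since both enter together in a single change. Going by these compounds alone, also open is whether a phenyl bearing an amine or a carboxylic acid at this place would move the number further than compound 3 at 21100 nM, which remains the only measured value.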